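The source may hold more compounds than are shown below. What is called first, only, known or untested is meant among the compounds shown, and "the series" means these compounds.

Measured compounds:
compound 1, `N#CN/C(=N\CCCCCCOc1ccccc1)Nc1ccncc1`, 30 nM
compound 2, `N#CN/C(=N\CCCCCOc1ccc(Cl)cc1)Nc1ccncc1`, 53 nM

In a functional assay on MCF7 cells (Homo sapiens) for antiproliferative activity (a higher number here means a weaker inhibitor, a lower number a stronger inhibitor), compound 1 gives 30 nM, and compound 2 gives 53 nM. The two numbers sit within the scatter of each other: a 1.8-fold higher number from compound 1 to compound 2 (0.25 log units; within the scatter), so neither compound can be called the more active of the pair.

Compound 3, `N#CN/C(=N\CCCCCCOc1cc(Cl)c(Cl)cc1Cl)Nc1ccncc1`, has not yet been measured in this assay. It differs from compound 1 in one place: 2,4,5-trichlorophenyl in place of phenyl on an oxygen on a saturated carbon.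

For the measured compounds named here, only one measured step bears on this change. The step from compound 1 to compound 2 also brings a chlorine onto the aromatic ring at the end of the chain, together with a change in the chain, and that step stayed within the scatter: a 1.8-fold higher number from compound 1 to compound 2 (0.25 log units; within the scatter). Compound 3 carries three chlorines on that ring rather than one, a change the measured pair does not cover directly. On the evidence at hand, no step beyond the scatter is expected for compound 3, with a slight lean toward a higher number: a 1.5-fold higher number from compound 1 to compound 3 (0.18 log units; within the scatter). Compound 3 is therefore estimated at 45 nM in this assay, within a range of 15 nM to 150 nM.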

Compound 3, half-maximal inhibitory concentration: 4.4 nM
For compound 3 the middle estimate is 10-fold (1.01 log units) above the measured one; measured number outside the range, below it.
By their numbers in this assay, from the lowest: compound 3; then compounds 1 and 2 (each within the scatter of the next).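

In this assay, 2,4,5-trichlorophenyl in place of phenyl on an oxygen on a saturated carbon gives a 6.8-fold lower number from compound 1 to compound 3 (0.83 log units; beyond the scatter). This is the first step among these compounds that lies beyond the scatter, whereas the one earlier step, which changed the chain as well as the ring substituent, could not be told apart from it. The group on this oxygen is thus shown to be a place where the number can move, and with the chain of compound 1 left unchanged it moves downward, though nothing available bears on why this happens.

Compound 2 differs from compound 1 in its chain as well as in its ring, and the compounds shown therefore do not separate what a single chlorine would do on the chain of compound 1 from what the three chlorines of compound 3 do together. They also leave open whether the lower number would hold on a shorter or longer chain, and whether a methoxy or trifluoromethyl group on the ring in place of chlorine would give a similar step.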